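This account rests on a few compounds, and the source may have more. Where it says the series, first, only, none or still open, it means among the compounds named here.

In an ADME assay on MT4 cells (Homo sapiens) for cytotoxicity, read by XTT assay, with a stated time of 5 days (a lower number here means that less compound is tolerated, a higher number that more compound is tolerated), compound 1 (`C=CCNC(=O)[C@@H](NC(=O)[C@@](O)(CCCN(Cc1ccc(Br)cc1)NC(=O)[C@@H](NC(=O)OC)C(C)(C)C)Cc1ccc(C=C)cc1)C(C)(C)C`) gives 44000 nM. Compound 2 (`C=CCNC(=O)[C@@H](NC(=O)[C@@](O)(CCCN(Cc1ccc(Br)cc1)NC(=O)[C@@H](NC(=O)OC)C(C)(C)C)Cc1ccc(CC=C)cc1)C(C)(C)C`) reads > 50000 nM, which is a limit of the assay and not a number. Compound 3 (`COC(=O)N[C@H](C(=O)NN(CCC[C@@]1(O)Cc2ccc(cc2)C/C=C\CNC(=O)[C@H](C(C)C)NC1=O)Cc1ccc(Br)cc1)C(C)(C)C`) reads > 50000 nM, again only a limit, and so stands at the limit of > 50000 nM in this assay, at which 2 of the 3 values shown sit.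

Compound 4 (`COC(=O)N[C@H](C(=O)NN(CCC[C@@]1(O)Cc2ccc(cc2)C/C=C\CNC(=O)[C@H](C(C)(C)C)NC1=O)Cc1ccc(Br)cc1)C(C)(C)C`) differs from compound 3 by methyl in place of hydrogen on a saturated chain carbon bound to two saturated chain carbons and a saturated ring carbon, which reads as isopropyl to tert-butyl. Within the data shown here, the only measured step is an at least 1.1-fold higher number from compound 1 to compound 2 (0.05 log units; that floor lies within the scatter), with allyl in place of vinyl on an aromatic carbon, a different change at a different place. It therefore bears only loosely, and no shift beyond the scatter is expected in this assay. The expected step is a number no higher from compound 3 to compound 4 (the limit leaves the size open). For compound 4 the estimated value is 50000 nM, within an expected range of 30000 nM to 80000 nM.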

Compound 4, half-maximal cytotoxic concentration: 30000 nM
Estimate against measurement, compound 4: 1.7-fold (0.22 log units) above; the range from low to high includes it.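

In this assay, the change from isopropyl to tert-butyl gives an at least 1.6-fold lower number from compound 3 to compound 4 (0.22 log units; that floor lies within the scatter). Compound 4 thus gives 30000 nM, a measured number at this position. The earlier compounds shown here offered only a limit here, and the printed floor does not establish a shift beyond the scatter. The true size of the step stays open because compound 3 holds only a limit: the limit of > 50000 nM in this assay, at which 2 of the 4 values shown sit.

The compounds shown leave open how an amine or a longer chain in place of tert-butyl would read in this assay.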